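Antiproliferative Screen: Varying the Amide on a Shared Core

The source may hold more compounds than are shown below. What is called first, only, known or untested is meant among the compounds shown, and "the series" means these compounds.

Measured compounds:
- compound 1, `CC(O)C(=O)Nc1cc(Oc2ccc(Nc3nccc4[nH]cc(-c5ccc(F)cc5)c(=O)c34)cc2F)ccn1`: 47.8%
- compound 2, `CC(C)(O)Cn1cc(-c2ccc(F)cc2)c(=O)c2c(Nc3ccc(Oc4ccnc(NC(=O)C5CC5)c4)c(F)c3)nccc21`: -2.6%

Working notes. Two members of this series have been run in a functional assay on HT-29 cells (Homo sapiens) for antiproliferative activity, read by MTT assay, with a stated time of 72 h, tested at 10 uM; a lower number here means less inhibition, a higher number more inhibition at the concentration tested (going by the name of the read-out). Compound 1 gives 47.8%, the higher of the two numbers, and compound 2 gives -2.6%, a gap that lies beyond the usual scatter. Within the data shown here, compound 2 differs from compound 1 in more than one place, so its values say only that the two compounds sit far apart; no single-step reading can be taken from them.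

Compound 3, `CC(C)(C)C(=O)Nc1cc(Oc2ccc(Nc3nccc4[nH]cc(-c5ccc(F)cc5)c(=O)c34)cc2F)ccn1`, is the next compound to go into this assay. It differs from compound 1 in one place: tert-butyl in place of 1-hydroxyethyl on a carbonyl carbon. The tert-butyl in place of 1-hydroxyethyl on the carbonyl carbon leaves the rest of the shared core untouched.

Among the measured compounds shown here, no measured pair in this set isolates a change at the carbonyl carbon, so nothing here sets the size of the step. Given that the only anchor is compound 1 at 47.8%, the expectation for compound 3 is a step no larger than the scatter, with a modest chance of a drop, expressed as a number 7.8 percentage points lower from compound 1 to compound 3 (within the scatter). Compound 3 is therefore estimated at 40%, within 10% to 70%.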

Compound 3, a percentage reported as inhibition, at one concentration (the size of the read-out at that concentration, not a potency): -45.8%
Estimate against measurement, compound 3: 85.8 percentage points above, outside the stated range (below it).
By their numbers in this assay, from the lowest: compound 3; then compound 2; then compound 1.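

In this assay, among these compounds, the carbonyl carbon of the amide is a highly sensitive place on the shared core, since tert-butyl in place of 1-hydroxyethyl gives a number 93.6 percentage points lower from compound 1 to compound 3 (beyond the scatter) and so provides the first single-place step. The value for compound 3, -45.8% as printed, is also negative, so this change does more than reduce the inhibition seen with compound 1 to nothing. The 1-hydroxyethyl group carries a hydrogen-bond donor and a hydrogen-bond acceptor while tert-butyl carries neither, but this one step cannot tie the result to that difference or to the change in the chain itself, and no measurement in hand explains its size.

Still open, as far as these compounds go, is whether 2-hydroxypropan-2-yl, which has the branched carbon of tert-butyl together with a hydroxyl, would read closer to compound 1 or closer to compound 3, and that comparison would help separate the two features changed here. Also open, from the compounds shown here alone, is how simpler groups on the same carbonyl carbon, such as methyl, hydroxymethyl or aminomethyl, would fall along the wide range these two compounds span.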